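The source may hold more compounds than are shown below. What is called first, only, known or untested is meant among the compounds shown, and "the series" means these compounds.

Measured so far:
compound 1 `O=S(=O)(c1ccc(F)c(F)c1)c1cnc2cc(F)ccc2c1-c1ccc(Cl)cc1` — 10 mg/kg
compound 2 `O=S(=O)(c1cc(Cl)cc(Cl)c1)c1cnc2c(F)cccc2c1-c1ccc(F)cc1` — 30 mg/kg
compound 3 `O=S(=O)(c1cc(Cl)cc(Cl)c1)c1cnc2cc(F)ccc2c1-c1cccc(F)c1` — 30 mg/kg

In a functional assay on the whole organism (strain Wistar) with Rattus norvegicus as the target (on this read-out lower numbers stand for an effect already at smaller amounts and higher numbers for an effect only at larger amounts of compound), compound 1 stands lowest of the three numbers; the values of compound 2 and compound 3 both lie beyond the scatter above it. Compound 4 `O=S(=O)(c1cc(Cl)cc(Cl)c1)c1cnc2cc(F)ccc2c1-c1ccc(Cl)cc1` is still to be measured. It differs from compound 1 in one place: 3,5-dichlorophenyl in place of 3,4-difluorophenyl on a sulfonyl sulfur. Going by the values given here, no measured pair differs by this change alone, so no step can be read off directly. Compound 2 and compound 3 both carry the 3,5-dichlorophenyl group, yet each also differs from compound 4 elsewhere, so their values give only a hint. A modest move toward a higher number in this assay is expected, a 2.0-fold higher number from compound 1 to compound 4 (0.30 log units; within the scatter), possibly within the scatter. The estimate for compound 4 is 20 mg/kg, with a range from 10 mg/kg to 60 mg/kg.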

Compound 4, minimum effective dose: 30 mg/kg
Compound 4: middle estimate off by 1.5-fold (0.18 log units), on the low side, and the stated range covers the measured number.
By their numbers in this assay, from the lowest: compound 1; then compounds 2, 3 and 4 (each within the scatter of the next).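

In this assay, going by these compounds alone, the swap to 3,5-dichlorophenyl in place of 3,4-difluorophenyl on the sulfonyl sulfur gives a 3.0-fold higher number from compound 1 to compound 4 (0.48 log units; beyond the scatter) as the first direct reading of this change. With 3,5-dichlorophenyl held on the sulfur, 4-chlorophenyl in place of 3-fluorophenyl on an aromatic carbon gives no change at the digits printed from compound 3 to compound 4 (within the scatter) and no separation in this read-out. No evidence is available that bears on this result.

Going by these compounds, whether the sulfonyl step holds with a group other than 4-chlorophenyl on the aromatic carbon remains open. So does the outcome with a methyl group or a pyridine ring on the sulfonyl sulfur.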